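From an Oxolanyloxycarbonyl to a Cyclobutylmethyl Substituent

The compounds below may be only part of what the source reports. "The series", "measured", "known", "first", "only" and "open" are said of these compounds alone.

Measured compounds:
Compound 1 `CC(C)(C)OC(=O)N1CCC(O[C@H]2CC[C@@H](Oc3ccc(S(C)(=O)=O)cc3)CC2)CC1` gives 121% in a functional assay on isolated protein for agonist activity at Glucose-dependent insulinotropic receptor (Rattus norvegicus), read by HTRF and cAMP accumulation; a lower number here means a smaller maximal response, a higher number a larger maximal response.
Compound 2 `C[C@@H](CF)OC(=O)N1CCC(O[C@H]2CC[C@H](Oc3cnc(S(C)(=O)=O)cn3)CC2)CC1` gives 123% in this assay.
Compound 3 `CS(=O)(=O)c1cnc(O[C@H]2CC[C@H](OC3CCN(C(=O)OC4CCOC4)CC3)CC2)cn1` gives 109% in this assay.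

Compound 3 stands lowest of the three in this assay, beyond the scatter from both compound 1 and compound 2. Compound 4 `CS(=O)(=O)c1cnc(O[C@H]2CC[C@H](OC3CCN(CC4(C(F)(F)F)CCC4)CC3)CC2)cn1` differs from compound 3 by a single change: (1-(trifluoromethyl)cyclobutyl)methyl in place of ((oxolan-3-yl)oxy)carbonyl on an amine nitrogen in a ring. Going by the values given here, the only measured step, a number 14 percentage points lower from compound 2 to compound 3 (beyond the scatter), swapped one group on the oxygen of the carbonyl for another, so it touches the same position but not the same kind of change; none of the measured steps removes the whole carbonyl-bearing group. The expectation therefore rests on weak ground, and a small downward step is estimated, a number 9 percentage points lower from compound 3 to compound 4 (within the scatter). Compound 4 is expected to give about 100% in this assay, within a range from 70% to 125%.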

Compound 4, largest response reached (Emax), in percent of the reference or control that the assay uses: 99%
The estimate for compound 4 lay 1 percentage points above the measured number, within the range that was stated.
By their numbers in this assay, from the lowest: compounds 4 and 3 (each within the scatter of the next); then compounds 1 and 2 (each within the scatter of the next).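

In this assay the whole ((oxolan-3-yl)oxy)carbonyl can leave the amine nitrogen in the ring for (1-(trifluoromethyl)cyclobutyl)methyl, with a number 10 percentage points lower from compound 3 to compound 4 (within the scatter) as the result, so a maximal response survives on this nitrogen with a group that has no carbonyl and no hydrogen-bond acceptors. Set against the group on compound 2, the same entering group gives a number 24 percentage points lower from compound 2 to compound 4 (beyond the scatter) in this comparison. Nothing measured here explains either step.

From the compounds shown here alone, what a plain cyclobutylmethyl group, without the trifluoromethyl, or a chain ending in a carboxylic acid would give on this nitrogen remains open.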